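The source may report more compounds than this note shows. Statements on the series, on what has been measured and on what is new or still open speak of the compounds shown alone.

Compound 1 `CNC(=O)c1cc(C(=O)N[C@H]2[C@@H]3COC[C@@H]32)cc2c1OC[C@H]2c1ccccc1`: >= 165 ug/mL
Compound 2 `CNC(=O)c1cc(C(=O)N[C@H]2[C@@H]3COC[C@@H]32)cc2c1O[C@H](CF)[C@H]2c1ccccc1`: >= 206 ug/mL
Compound 3 `CNC(=O)c1cc(C(=O)NC2CC2)cc2c1OC[C@H]2c1ccccc1`: >= 190 ug/mL

All three compounds were tested in a physicochemical assay for solubility (a higher number here means a more soluble compound, a lower number a less soluble compound), and each reading is a limit of the assay, not a number. Compound 2, the starting point here, gives the limit >= 206 ug/mL.

Compound 4 `CNC(=O)c1cc(C(=O)NCCC[C@H]2OC[C@H](N)CO2)cc2c1O[C@H](CF)[C@H]2c1ccccc1` has not yet been measured. It keeps the fluoromethyl group of compound 2 and differs on an amide-type nitrogen: a group of 10 heavy atoms (7 carbon, 1 nitrogen, 2 oxygen; one six-membered non-aromatic ring with 2 hetero atoms) in place of a group of 6 heavy atoms (5 carbon, 1 oxygen; one three-membered non-aromatic ring of carbon only, one five-membered non-aromatic ring with 1 hetero atom), on an amide-type nitrogen.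

Going by the values given here, two measured steps bear on this change. The closer one also swaps a group on an amide-type nitrogen, and it is a step that the two limits leave unreadable from compound 1 to compound 3. The other is fluoromethyl in place of hydrogen on a saturated ring carbon, and it is a step that the two limits leave unreadable from compound 1 to compound 2. Neither step has a readable size, so neither offers a size or a direction to carry over, and the group entering compound 4 has not been tested in any measured compound. No step beyond the usual scatter is therefore expected in this assay, though this is a weak expectation. The estimated change is an at least 1.0-fold lower number from compound 2 to compound 4 (0.01 log units; that floor lies within the scatter). For compound 4 the expected value is 200 ug/mL, with an estimated range of 110 ug/mL to 320 ug/mL.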

Compound 4, solubility: 174 ug/mL
For compound 4 the middle estimate is 1.1-fold (0.06 log units) above the measured one; measured number inside the range.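

In this assay, going by these compounds alone, compound 4 gives 174 ug/mL, the first reading in this set that is a number and not a limit, so the group on the amide-type nitrogen now has one exact value to build on; the earlier steps, at this nitrogen and at the fluoromethyl group, cannot be read. The new step is an at least 1.1-fold lower number from compound 2 to compound 4 (0.07 log units; that floor lies within the scatter), which shows that replacing the group with two fused small rings by the larger one with a single six-membered ring gives no drop beyond the scatter at that floor. The true size of the change remains unknown because compound 2 gives only a limit: the limit of >= 206 ug/mL in this assay, at which 1 of the 4 values shown sits.

The compounds shown leave open which part of the entering group accounts for the reading: the amine, the two ring oxygens or the chain that links the ring to the amide-type nitrogen. Going by these compounds, it is also open how a carboxylic acid in place of that amine, or a longer chain with the same six-membered ring, would read in this assay.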